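The source may report more compounds than this note shows. Statements on the series, on what has been measured and on what is new or still open speak of the compounds shown alone.

Compound 1 `CC(C)(C)Cc1c(-c2ccc(F)cc2F)sc(N)c1C(=O)c1ccc(Cl)cc1`: 1%
Compound 2 `Cc1ccc(C(=O)c2c(N)sc(Br)c2CC(C)(C)C)cc1`: 1%
Compound 3 `COc1ccc(-c2sc(N)c(C(=O)c3cccc(C(F)(F)F)c3)c2CC(C)(C)C)cc1`: 1%

All three were tested in an assay on CHO cells for displacement of a labelled ligand from adenosine receptor A3 (Homo sapiens), read by scintillation counting, tested at 10 uM; on this read-out lower numbers stand for less inhibition and higher numbers for more inhibition at the one concentration tested (going by the name of the read-out). In this assay compound 1 gives 1%, which stands level with compound 2 at 1% and with compound 3 at 1%; the three readings lie within the usual scatter of one another, so none can be set apart.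

Compound 4 `CC(C)(C)Cc1c(-c2ccsc2)sc(N)c1C(=O)c1ccc(Cl)cc1` is not yet measured. It differs from compound 1 in one place: thiophen-3-yl in place of 2,4-difluorophenyl on an aromatic carbon. Among the compounds with values here, no two measured compounds differ by a single change, so this swap has no precedent here. Because compound 1 gives 1% and compounds 2 and 3, carrying other groups in place of the 2,4-difluorophenyl, read the same, the step is expected to be none beyond the scatter, a number 2 percentage points higher from compound 1 to compound 4 (within the scatter). Compound 4 is therefore estimated at 3%, ranging from 0% to 15%.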

Compound 4, a percentage reported as inhibition, at one concentration (the size of the read-out at that concentration, not a potency): 4%
Compound 4: middle estimate off by 1 percentage points, on the low side; low and high end bracket the measured number.
By their numbers in this assay, from the lowest: compounds 1, 2, 3 and 4 (each within the scatter of the next).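

In this assay, thiophen-3-yl in place of 2,4-difluorophenyl gives a number 3 percentage points higher from compound 1 to compound 4 (within the scatter). Within the data shown here, this is the first one-place comparison at this aromatic carbon, and it shows that exchanging a six-membered carbon ring for a five-membered ring with one sulfur leaves the reading within the scatter. Nothing available explains this result.

On these data alone, whether a different kind of group on this carbon, such as an amine or a carboxylic acid, would give a reading beyond the scatter stays open. So does the outcome of replacing the neopentyl group with a shorter chain, such as ethyl.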